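The source may hold more compounds than are shown below. What is called first, only, known or untested is meant among the compounds shown, and "the series" means these compounds.

Series notes: In a functional assay on NCI-H322M cells (Homo sapiens) for inhibition, read by sulforhodamine B assay, with a stated time of 48 h (on this read-out higher numbers stand for weaker inhibition of growth and lower numbers for stronger inhibition of growth), compound 1 (`O=C(Nc1cccc(-n2cc(-c3ccncc3)c(-c3ccc(Cl)c(O)c3)n2)c1)Nc1cccc(C(F)(F)F)c1`) gives 6410 nM, compound 2 (`COc1cc(-c2nn(-c3cccc(NC(=O)Nc4cc(C(F)(F)F)cc(C(F)(F)F)c4)c3)cc2-c2ccncc2)ccc1Cl`) gives 1020 nM and compound 3 (`COc1cc(-c2nn(-c3cccc(NC(=O)c4cccc(C(F)(F)F)c4)c3)cc2-c2ccncc2)ccc1Cl`) gives 10800 nM. The value of compound 3 lies within the scatter of compound 1, while compound 2 reads lower than compound 3 by a margin beyond the scatter.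

Compound 4 (`COc1cc(-c2nn(-c3cccc(NC(=O)c4ccc(Cl)c(C(F)(F)F)c4)c3)cc2-c2ccncc2)ccc1Cl`) departs from compound 3 by one change, chloro in place of hydrogen on an aromatic carbon, ortho to a trifluoromethyl group and para to a large group. This turns 3-(trifluoromethyl)phenyl into 4-chloro-3-(trifluoromethyl)phenyl.

Going by the values given here, no measured pair differs in one place, so no direct precedent exists for this change. Compound 2, at 1020 nM, carries two trifluoromethyl groups on its terminal ring, which gives weak support for a lower number, but it differs from compound 3 in more than one place. The expected move, a 1.8-fold lower number from compound 3 to compound 4 (0.26 log units; within the scatter), is toward a lower number and stays within the scatter. For compound 4 the estimated value in this assay is 6000 nM, with an expected range of 2500 nM to 13000 nM.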

Compound 4, concentration for 50% growth inhibition: 12800 nM
The estimate for compound 4 lay 2.1-fold (0.33 log units) below the measured number; the measured number falls inside the stated range.
By their numbers in this assay, from the lowest: compound 2; then compounds 1, 3 and 4 (each within the scatter of the next).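

In this assay, going by these compounds alone, the step of a 1.2-fold higher number from compound 3 to compound 4 (0.07 log units; within the scatter) is the first single-place comparison. It shows that chloro can stand on this aromatic carbon, ortho to a trifluoromethyl group and para to a large group, without moving the number beyond the scatter, so 4-chloro-3-(trifluoromethyl)phenyl and 3-(trifluoromethyl)phenyl read alike here. No measured evidence bears on why the two read alike.

From the compounds shown here alone, whether an amine or a carboxylic acid at this same position would also read alike remains open. Also open, going by these compounds, is whether chloro at this position would read the same on a urea-bearing compound such as compound 1, since this single step covers only the amide pair.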